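The compounds below may be only part of what the source reports. "The series", "measured", "known", "first", "only" and "open" are said of these compounds alone.

Working notes on the series. Compound 1 `CC(C)c1onc(-c2c(Cl)cccc2Cl)c1COc1ccc(-c2nc3ccc(C(=O)O)cc3n2Cc2ccc(F)cc2)cc1` is the reference point of the set. In an assay on Huh-7 cells for agonist activity at Bile acid receptor (Homo sapiens), read by a luciferase reporter (on this read-out lower numbers stand for an effect already at smaller amounts and higher numbers for an effect only at larger amounts of compound), compound 1 gives 3.31 nM, the lowest of the two numbers recorded so far. Compound 2 `CC(C)c1onc(-c2c(Cl)cccc2Cl)c1COc1ccc(-c2nc3cc(C(=O)O)ccc3n2C)cc1` differs from compound 1 in several places at once. In this assay compound 2 gives 25.8 nM; the gap between the two numbers lies beyond the usual scatter, but with several changes between them nothing can be tied to any single one. Among the measured compounds shown here, no pair of measured compounds that differ in only one place exists in the set, so no measured step is available to anchor an expectation.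

Compound 3 `CC(C)c1onc(-c2c(Cl)cccc2Cl)c1COc1ccc(-c2nc3ccc(C(=O)O)cc3n2-c2ccc(F)cc2)cc1` has not yet been measured in this assay. It differs from compound 1 by 4-fluorophenyl in place of 4-fluorobenzyl on an aromatic nitrogen, so that the fluorinated ring now sits directly on the aromatic nitrogen. With no measured step of this kind in the set, the direction of the change cannot be read from the data. The expectation for the step of a 2.4-fold higher number from compound 1 to compound 3 (0.38 log units; beyond the scatter) is a modest shift toward a higher number, of a size that may or may not exceed the scatter. Compound 3 is therefore estimated at 8 nM, with a range from 2.5 nM to 30 nM.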

Compound 3, half-maximal effective concentration: 32.2 nM
Compound 3: the middle estimate sits 4.0-fold (0.60 log units) below what was measured; measured number above the stated range.
By their numbers in this assay, from the lowest: compound 1; then compounds 2 and 3 (each within the scatter of the next).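

Among the compounds shown here, this is the first step in the set confined to one place, and it shows that the group on the aromatic nitrogen matters in this assay: 4-fluorophenyl in place of 4-fluorobenzyl gives a 9.7-fold higher number from compound 1 to compound 3 (0.99 log units; beyond the scatter), beyond the scatter. The two groups share a six-membered aromatic ring of carbon only and the fluorine, and neither carries hydrogen-bond donors, hydrogen-bond acceptors or a net charge; they differ in count, with 8 heavy atoms leaving and 7 entering, and the fluorinated ring now sits directly on the aromatic nitrogen. No measurement in hand accounts for the size of this step.

The compounds shown leave open how the number responds to a longer chain on this nitrogen, such as 2-(4-fluorophenyl)ethyl, and whether the fluorine plays any part, which a plain benzyl on the core of compound 1 would address. The methyl on the nitrogen of compound 2 cannot fill this gap, as that compound differs from compound 1 in several places at once.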